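A few compounds are considered here, and "the series" means these few. Any claim that something is new, unique, unknown or untested is made for them only; others in the source may bear on it.

In a functional assay on T47D cells (Homo sapiens) for cytotoxicity, read by sulforhodamine B assay, with a stated time of 48 h, tested at 10 uM (on this read-out lower numbers stand for a stronger effect and higher numbers for a weaker effect at the one concentration tested), compound 1 `COc1cc(-c2cc(/C=C/C(=O)c3ccc(N)cc3)[nH]n2)cc(OC)c1OC` gives -38%; compound 2 `COc1ccc(-c2cc(/C=C/C(=O)c3ccc(N)cc3)[nH]n2)cc1OC` gives 28%; compound 3 `COc1cc(C(=O)/C=C/c2cc(-c3cc(OC)c(OC)c(OC)c3)n[nH]2)cc(OC)c1OC` gives -82%.

Compound 3 stands lowest of the three. Between compound 1 and compound 2 the change is hydrogen in place of methoxy on an aromatic carbon, and it made the step of a number 66 percentage points higher from compound 1 to compound 2 (beyond the scatter). Compound 3 and compound 1 differ in more than one place, so the difference between the two cores is not broken down here.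

Compound 4 `COc1ccc(-c2cc(/C=C/C(=O)c3cc(OC)c(OC)c(OC)c3)[nH]n2)cc1OC` carries the same change relative to compound 3, namely (hydrogen in place of methoxy on an aromatic carbon), at a place described in the same words as before. Because a number 66 percentage points higher from compound 1 to compound 2 (beyond the scatter) was large, the step from compound 3 to compound 4 is estimated at a number 62 percentage points higher from compound 3 to compound 4 (beyond the scatter). Compound 4 is therefore expected to give about -20% in this assay, within a range from -60% to 20%.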

Compound 4, a percentage reported as activity, at one concentration (the size of the read-out at that concentration, not a potency): -37%
The estimate for compound 4 lay 17 percentage points above the measured number; the measured number falls inside the stated range.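

In this assay, hydrogen in place of methoxy again moved the read-out towards a weaker effect, with a number 45 percentage points higher from compound 3 to compound 4 (beyond the scatter) and thus the same direction as on the core of compound 1. The direction carried over from one core to the other, but the size did not: the same change on two cores in this assay, a number 66 percentage points higher (beyond the scatter) from compound 1 to compound 2 and a number 45 percentage points higher (beyond the scatter) from compound 3 to compound 4, 21 percentage points apart, beyond the scatter of two such steps. These two pairs do not supply a size that could be applied to a further core, and they do not explain why the two steps differ.

The compounds shown leave open how a hydroxyl group, a fluorine atom or a longer alkoxy chain would behave at this place. They also leave open whether a carboxylic acid on the aromatic ring would change the read-out.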